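This account rests on a few compounds, and the source may have more. Where it says the series, first, only, none or still open, it means among the compounds named here.

Three compounds share one core and differ only in the aryl group on a saturated chain carbon, two bonds along the chain from an oxygen on an aromatic ring. Compound 1 `Cc1ccc(CCOc2ccc(-c3c(C)nc(C)c([C@H](OC(C)(C)C)C(=O)O)c3N3CCC(C)(C)CC3)cc2)cc1` carries a 4-methylphenyl there, compound 2 `COc1cccc(CCOc2ccc(-c3c(C)nc(C)c([C@H](OC(C)(C)C)C(=O)O)c3N3CCC(C)(C)CC3)cc2)c1` a 3-methoxyphenyl, and compound 3 `Cc1nc(C)c([C@H](OC(C)(C)C)C(=O)O)c(N2CCC(C)(C)CC2)c1-c1ccc(OCCc2ccc(F)cc2F)cc1` a 2,4-difluorophenyl. In a toxicity assay on MT2 cells (Homo sapiens) for cytotoxicity, read by XTT assay, with a stated time of 4 days (a higher number here means that more compound is tolerated, a lower number that less compound is tolerated), compound 1 gives only a limit, >= 33500 nM. Compound 2 likewise reaches only a limit, >= 33500 nM. Compound 3 too stops at a limit, >= 33500 nM. The steps a step that the two limits leave unreadable from compound 1 to compound 2, a step that the two limits leave unreadable from compound 1 to compound 3 and a step that the two limits leave unreadable from compound 2 to compound 3 therefore cannot be read, because of the limit of >= 33500 nM in this assay, at which 3 of the 3 values shown sit. Compound 2 thus stands at the limit, as do the two other values shown. Compound 4 `Cc1nc(C)c([C@H](OC(C)(C)C)C(=O)O)c(N2CCC(C)(C)CC2)c1-c1ccc(OCCc2ccncc2)cc1` follows from compound 2 by pyridin-4-yl in place of 3-methoxyphenyl on a saturated chain carbon, two bonds along the chain from an oxygen on an aromatic ring. Within the data shown here, no measured step bears on this change in a readable way, since every aryl variation so far has left the value at the limit. The expectation is therefore that compound 4 also sits at the limit, with the step of a number no higher from compound 2 to compound 4 (the limit leaves the size open) expected to show nothing beyond the scatter. Compound 4 is estimated at 33500 nM, between 15000 nM and 70000 nM.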

Compound 4, half-maximal cytotoxic concentration: >= 25000 nM
Compound 4 was reported as a limit; the forecaster's own chance of this, stated with the estimate: 85%; the middle value does not contradict the limit.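

In this assay compound 4 also gives only a limit, >= 25000 nM, so its steps from compound 1, compound 2 and compound 3 cannot be read: the limit of >= 25000 nM in this assay, at which 1 of the 4 values shown sits.

The compounds shown leave open at what concentration any of them becomes cytotoxic, and whether the aryl group changes that concentration.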